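Taking the Cyclopentylmethoxy Group off Compound 2

This account rests on a few compounds, and the source may have more. Where it says the series, first, only, none or still open, it means among the compounds named here.

In a functional assay on PC-12 cells (Rattus norvegicus) for inhibition, read by sulforhodamine B assay (a lower number here means a stronger inhibitor, a higher number a weaker inhibitor), compound 1 (`Cc1c(C)c2c(c(C)c1O)CCC(C)(COc1ccc(/C=C3/SC(=O)NC3=O)cc1)O2`) gives 5000 nM and compound 2 (`O=C1NC(=O)C(Cc2ccc(OCC3CCCC3)cc2)S1`) gives 25000 nM as the higher of the two numbers, a gap beyond the usual scatter. These two compounds differ in more than one place, so their gap cannot be assigned to any single group.

Compound 3 (`O=C1NC(=O)C(Cc2ccccc2)S1`) is a plainer relative of compound 2, and the change is hydrogen in place of cyclopentylmethoxy on an aromatic carbon with hydrogen in place of cyclopentylmethoxy on an aromatic carbon. Going by the values given here, no measured pair in this small set shows such a change, so any forecast remains a judgment.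

Compound 2 already sits at 25000 nM and compound 3 keeps nothing of its cyclopentylmethoxy. A modest step upward in this assay is therefore expected, toward a weaker inhibitor and probably just beyond the scatter. The estimated size of this expected change is a 2.4-fold higher number from compound 2 to compound 3 (0.38 log units; beyond the scatter) on the present reasoning. Compound 3 is expected at 60000 nM with an estimated range of 25000 nM to 150000 nM in this test.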

Compound 3, half-maximal inhibitory concentration: > 100000 nM
Compound 3 gave a limit, no number (the forecaster's own chance of this, stated with the estimate: 30%); middle value at least 1.6-fold (0.22 log units) from the limit.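

In this assay compound 3 gives > 100000 nM, which is a limit of the assay and not a number. Hydrogen in place of cyclopentylmethoxy on an aromatic carbon gives an at least 4.0-fold higher number from compound 2 to compound 3 (0.60 log units; beyond the scatter); this is the only comparison here in which just one place changes, and it shows that the measurable inhibition of compound 2 depends on having cyclopentylmethoxy rather than hydrogen at this position, para to a group of 8 heavy atoms. The step sets only a lower bound, and its full size cannot be read from a result that stands at a limit: the limit of > 100000 nM in this assay, at which 1 of the 3 values shown sits.

The compounds shown leave open which part of the cyclopentylmethoxy group matters, since a methoxy, a hydroxyl or a longer chain on this aromatic carbon would separate the oxygen from the five-membered ring of carbon. They also leave open whether an amine or a carboxylic acid at this position would keep compound 2's level of inhibition, or whether the same exchange would have a similar effect on a different core, such as that of compound 1.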